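Removing an isopropyl from the ring nitrogen of compound 2

The source may hold more compounds than are shown below. What is called first, only, known or untested is meant among the compounds shown, and "the series" means these compounds.

Of the compounds shown here, two have been measured in an assay for inhibition of Tryptophan 2,3-dioxygenase (Homo sapiens), with stated times of 10 min and 60 min, tested at 100 uM; on this read-out higher numbers stand for a stronger effect at the one concentration tested and lower numbers for a weaker effect. Compound 1 `O=[N+]([O-])c1ccccc1CNc1cc(Br)cc2[nH]ncc12` carries a bromine on the shared core and a free hydrogen on the ring nitrogen; in this assay compound 1 gives 64%. Compound 2 `CC(C)n1ncc2c(NCc3ccccc3[N+](=O)[O-])cc(C(F)(F)F)cc21` carries a trifluoromethyl in place of the bromine and an isopropyl on the ring nitrogen; in this assay compound 2 gives 32%. Of the two numbers, compound 2 stands at the lower one, with compound 1 lying higher by a gap that is beyond the usual scatter of repeated measurements.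

Compound 3 `O=[N+]([O-])c1ccccc1CNc1cc(C(F)(F)F)cc2[nH]ncc12` has not yet been measured. It differs from compound 2 in one place: hydrogen in place of isopropyl on an aromatic nitrogen. Going by the values given here, no step between measured compounds shows this change by itself, so its size cannot be read from the numbers at hand. Since compound 3 shares the free ring nitrogen with compound 1, whose value is 64%, the expected step of a number 18 percentage points higher from compound 2 to compound 3 (beyond the scatter) is upward, of a size likely beyond the scatter. Compound 3 is therefore estimated to give 50%, within a range from 25% to 75%.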

Compound 3, a percentage reported as inhibition, at one concentration (the size of the read-out at that concentration, not a potency): 95%
Compound 3: middle estimate off by 45 percentage points, on the low side; measured number above the stated range.
By their numbers in this assay, from the lowest: compound 2; then compound 1; then compound 3.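

In this assay, hydrogen in place of isopropyl on the aromatic nitrogen can now be read as a change on its own, and it gives a number 63 percentage points higher from compound 2 to compound 3 (beyond the scatter), so what sits on this nitrogen clearly matters for the read-out. With that nitrogen free in both compounds, trifluoromethyl in place of bromo on an aromatic carbon gives a number 31 percentage points higher from compound 1 to compound 3 (beyond the scatter), which separates the two changes that were mixed together in the earlier pair and shows that the trifluoromethyl compound need not be the lower one. Nothing measured here explains why either change raises the number.

Hydrogen and isopropyl are the only groups shown on this nitrogen, so it remains open whether a methyl or an ethyl would stay close to compound 3, fall close to compound 2, or land in between. As far as these compounds go, it also remains open whether the isopropyl costs as much with bromo on the core, and how a nitrile or a carboxylic acid would compare with trifluoromethyl at that carbon.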